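The compounds below may be only part of what the source reports. "The series", "measured", "known", "first", "only" and "open" are said of these compounds alone.

Of the compounds shown here, two have been measured in a functional assay on HEK293 cells for agonist activity at probable G-protein coupled receptor 27 (Homo sapiens), read by a luciferase reporter and beta-arrestin recruitment, with a stated time of 10 min; on this read-out lower numbers stand for an effect already at smaller amounts and higher numbers for an effect only at larger amounts of compound. Compound 1 `O=C(Nc1ccc(S(=O)(=O)Nc2ccccc2)cc1)c1ccc(Cl)nc1F` gives 2290 nM, and compound 2 `O=C(Nc1ccc(S(=O)(=O)Nc2ccccc2)cc1)c1ccc(Cl)cc1F` gives 3980 nM. Compound 2 holds the higher of the two numbers, yet the step of a 1.7-fold higher number from compound 1 to compound 2 (0.24 log units; within the scatter) is the only one available, and it stays within the scatter, so the two compounds cannot be told apart on these figures.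

Compound 3 `O=C(Nc1ccc(S(=O)(=O)Nc2ccccc2)cc1)c1ccc(Cl)cc1Br` differs from compound 2 in one place: bromo in place of fluoro on an aromatic carbon. Going by the values given here, no measured step exchanges one halogen for another on this ring. Among the compounds with values here, the single known step, a 1.7-fold higher number from compound 1 to compound 2 (0.24 log units; within the scatter), alters the ring itself and where the chloro group sits, so it gives no direct guide to a fluoro-to-bromo exchange. With nothing in the data pointing either way, the expectation is that compound 3 stays close to compound 2 in this assay. The step of a 1.1-fold lower number from compound 2 to compound 3 (0.06 log units; within the scatter) is expected to fall inside the usual scatter. Compound 3 is therefore estimated at 3500 nM, with a range from 1000 nM to 12000 nM, the breadth reflecting how little the measured pair says about this particular change.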

Compound 3, half-maximal effective concentration: 1020 nM
The estimate for compound 3 lay 3.4-fold (0.54 log units) above the measured number, and the stated range covers the measured number.
By their numbers in this assay, from the lowest: compound 3; then compounds 1 and 2 (each within the scatter of the next).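

In this assay, going by these compounds alone, this aromatic carbon, ortho to a large group, turns out to be sensitive to which halogen it carries: bromo in place of fluoro gives a 3.9-fold lower number from compound 2 to compound 3 (0.59 log units; beyond the scatter), a modest change, but the first single-atom exchange here that clears the scatter. Within the data shown here, the earlier pair could not show this, since its only step changed the ring and stayed within the scatter, so it gave no sign that any part of this end of the molecule mattered for the read-out. The step of a 2.2-fold lower number from compound 1 to compound 3 (0.35 log units; beyond the scatter) also lies beyond the scatter, but it swaps the whole 6-chloro-2-fluoropyridin-3-yl group for 2-bromo-4-chlorophenyl, so it cannot be pinned on the bromo alone, and nothing available explains either step.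

The compounds shown leave open whether the trend runs on through the halogens to iodo, or whether a chloro, a methyl or a methoxy group on the same carbon would serve as well as bromo. They also leave open whether bromo in place of fluoro would bring a similar step on the ring of compound 1.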